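Predicting Compound 3: a Methylamide Replaces the Acid

The source may hold more compounds than are shown below. What is called first, only, known or untested is meant among the compounds shown, and "the series" means these compounds.

Compound 1, `FC(F)(F)c1cccc(CNc2cc(C(F)(F)F)cc3[nH]ncc23)c1`, gives 40% in an assay for inhibition of Tryptophan 2,3-dioxygenase (Homo sapiens), with stated times of 10 min and 60 min, tested at 10 uM; a higher number here means a stronger effect of the compound at the concentration tested, a lower number a weaker effect.
Compound 2, `O=C(O)c1cccc(CNc2cc(C(F)(F)F)cc3[nH]ncc23)c1`, gives 81% in this assay.

Among the measured compounds shown here, compound 2 stands highest of the two measured compounds; its only neighbour, compound 1, lies lower by a number 41 percentage points higher from compound 1 to compound 2 (beyond the scatter). Compound 3, `CNC(=O)c1cccc(CNc2cc(C(F)(F)F)cc3[nH]ncc23)c1`, differs from compound 2 by methylamino in place of hydroxy on a carbonyl carbon. For the measured compounds named here, no measured step covers this exact change; the one step known, a number 41 percentage points higher from compound 1 to compound 2 (beyond the scatter), only shows that swapping the group at this part of the molecule can shift the read-out strongly. Compound 3 is therefore expected to lose some of the effect of compound 2, by a number 26 percentage points lower from compound 2 to compound 3 (beyond the scatter), giving an estimated 55% with a range from 30% to 80%.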

Compound 3, a percentage reported as inhibition, at one concentration (the size of the read-out at that concentration, not a potency): 71%
Compound 3: middle estimate off by 16 percentage points, on the low side; low and high end bracket the measured number.
By their numbers in this assay, from the lowest: compound 1; then compounds 3 and 2 (each within the scatter of the next).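

In this assay the swap of hydroxy for methylamino on a carbonyl carbon gives a number 10 percentage points lower from compound 2 to compound 3 (within the scatter) and so a free carboxylic acid is not required for a high read-out at this position. The change from trifluoromethyl to methylcarbamoyl on an aromatic carbon gives a number 31 percentage points higher from compound 1 to compound 3 (beyond the scatter) and so the gain over compound 1 is not unique to carboxy. Nothing available explains these results.

On these data alone, whether a primary carboxamide, an ethylamide or a nitrile would hold the read-out stays open. As far as these compounds go, each read-out shows the size of the effect at a single concentration, and whether the effect would be stronger or weaker at any other concentration also stays open.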